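The compounds below may be only part of what the source reports. "The series", "measured", "known", "first", "only" and "open" are said of these compounds alone.

Measured compounds:

Compound 1 `COC1CCN(CC(=O)N2CCN(c3sc(C(F)(F)F)nc3-c3nc4ccccc4[nH]3)C[C@H]2C)C1` gives 3380 nM in a functional assay on Venous blood for antagonist activity at C-X-C chemokine receptor type 3 (Homo sapiens), read by flow cytometry, with a stated time of 30 min, in the presence of a further agent that is not named here; on this read-out higher numbers stand for weaker inhibition and lower numbers for stronger inhibition.
Compound 2 `Cc1nc(C)n(CC(=O)N2CCN(c3sc(C(F)(F)F)nc3-c3nc4c(F)cccc4[nH]3)C[C@H]2C)n1` gives 321 nM in this assay.
Compound 3 `Cc1nn(CC(=O)N2CCN(c3sc(C(F)(F)F)nc3-c3nc4ccccc4[nH]3)C[C@H]2C)cc1CN(C)C` gives 330 nM in this assay.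

Among these three, compound 1 stands at the highest number: compound 3 comes closest, and compound 2 lies furthest away, both well beyond the scatter. Compound 2 differs from compound 1 in more than one place, so its values only show that it sits lower. For the measured compounds named here, the single step that bears on the change at hand is a 10-fold lower number from compound 1 to compound 3 (1.01 log units; beyond the scatter), a large drop obtained by exchanging the group on the saturated chain carbon bound to the carbonyl carbon.

Compound 4 `C[C@@H]1CN(c2sc(C(F)(F)F)nc2-c2nc3ccccc3[nH]2)CCN1C(=O)CN1C(=O)OC[C@@H]1c1ccccc1` carries the change (2-oxo-4-phenyl-1,3-oxazolidin-3-yl in place of 3-methoxypyrrolidin-1-yl on a saturated chain carbon bound to a carbonyl carbon). Going by the values given here, only one measured step touches that position, and the group entering compound 4 is not the one entering compound 3, so the expectation is cautious. Among the compounds with values here, still, since the one change recorded at this position gave a 10-fold lower number from compound 1 to compound 3 (1.01 log units; beyond the scatter), a lower number is expected for compound 4 than for compound 1, with the estimated step of a 3.8-fold lower number from compound 1 to compound 4 (0.57 log units; beyond the scatter). The estimate for compound 4 in this assay is 900 nM, within a range of 200 nM to 4000 nM.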

Compound 4, half-maximal inhibitory concentration: 1380 nM
Compound 4: middle estimate off by 1.5-fold (0.19 log units), on the low side; the measured number falls inside the stated range.
By their numbers in this assay, from the lowest: compounds 2 and 3 (each within the scatter of the next); then compound 4; then compound 1.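

In this assay, the saturated chain carbon bound to a carbonyl carbon now has a second replacement for 3-methoxypyrrolidin-1-yl, and 2-oxo-4-phenyl-1,3-oxazolidin-3-yl also lowers the number (a 2.4-fold lower number from compound 1 to compound 4 (0.39 log units; beyond the scatter)). The two entering groups do not count alike at this place, as going over to 2-oxo-4-phenyl-1,3-oxazolidin-3-yl from 4-((dimethylamino)methyl)-3-methyl-1H-pyrazol-1-yl raises the number (a 4.2-fold higher number from compound 3 to compound 4 (0.62 log units; beyond the scatter)). No evidence on hand accounts for this difference between the two groups.

On these data alone, it remains open how a 2-oxo-1,3-oxazolidin-3-yl group without the phenyl ring, or the opposite configuration at the defined stereocentre, would read. As far as these compounds go, a morpholine or a carboxylic acid on the same carbon is equally open.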